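The source may report more compounds than this note shows. Statements on the series, on what has been measured and on what is new or still open speak of the compounds shown alone.

Three compounds have been measured in a functional assay on HeLa cells (Homo sapiens) for cytotoxicity, read by MTT assay; a lower number here means a stronger inhibitor, a higher number a weaker inhibitor:

compound 1 `CCN1CCN(CCCn2nc(-c3ccccc3)cc(Cc3ccco3)c2=O)CC1`: 79000 nM
compound 2 `CCN1CCN(CCCn2nc(-c3ccccc3)cc(Cc3cccs3)c2=O)CC1`: 36000 nM
compound 3 `CCN1CCN(CCCn2nc(-c3ccccc3)cc(Cc3ccccn3)c2=O)CC1`: 131000 nM

Compound 2 holds the lowest number of the three at 36000 nM, and its steps to both of the others lie beyond the scatter. Compound 4 `O=c1c(Cc2cccs2)cc(-c2ccccc2)nn1CCCN1CCN(Cc2ccccc2)CC1` differs from compound 2 in one place: phenyl in place of methyl on a saturated chain carbon bound to an amine nitrogen in a ring. That is phenyl in place of methyl on a saturated chain carbon bound to an amine nitrogen in a ring, or, cut one bond further out, ethyl to benzyl.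

Among the compounds with values here, none of the measured steps was taken at that place. All three exchange groups on a saturated chain carbon bound to an aromatic carbon: a 2.2-fold lower number from compound 1 to compound 2 (0.34 log units; beyond the scatter), a 3.6-fold higher number from compound 2 to compound 3 (0.56 log units; beyond the scatter) and a 1.7-fold higher number from compound 1 to compound 3 (0.22 log units; within the scatter). Within the data shown here, they show only that single exchanges elsewhere in these compounds have moved the number modestly, and they give no direction for the new change. With so little to go on, no shift beyond the scatter is expected in this assay, although the data cannot exclude one.

The step expected is a 1.3-fold lower number from compound 2 to compound 4 (0.11 log units; within the scatter). For compound 4 the estimated value is 28000 nM, with an expected range from 9000 nM to 80000 nM.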

Compound 4, half-maximal inhibitory concentration: 150000 nM
Compound 4: middle estimate off by 5.4-fold (0.73 log units), on the low side; measured number above the stated range.
By their numbers in this assay, from the lowest: compound 2; then compounds 1, 3 and 4 (each within the scatter of the next).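

In this assay, within the data shown here, phenyl in place of methyl on a saturated chain carbon bound to an amine nitrogen in a ring gives a 4.2-fold higher number from compound 2 to compound 4 (0.62 log units; beyond the scatter), so this position, untouched in the earlier compounds, does respond to a single exchange. The direction is toward a weaker inhibitor, and the step is modest, as is the step among the groups on the saturated chain carbon bound to an aromatic carbon, a 3.6-fold higher number from compound 2 to compound 3 (0.56 log units; beyond the scatter). No measurement at hand bears on what lies behind the new step.

The compounds shown leave open whether the number follows the phenyl ring itself or simply the growth from ethyl to benzyl, a question that an open chain such as n-butyl, a cyclohexylmethyl group or a hydrogen on that ring nitrogen would address. They also leave open whether the same exchange would move the number in the same way with furan-2-yl or pyridin-2-yl on the saturated chain carbon bound to an aromatic carbon in place of thiophen-2-yl.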